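The source may hold more compounds than are shown below. What is called first, only, known or untested is meant among the compounds shown, and "the series" means these compounds.

Compound 1 `CCCC[C@H](NC(=O)[C@H](CCCCN)NC(=O)[C@H](CCCNC(=N)N)NC(=O)c1ccc(/C=C/C(N)=O)cc1)C(N)=O` is recorded in an ADME assay for permeability, using PAMPA (on this read-out lower numbers stand for lower permeability and higher numbers for higher permeability), as "impermeable" (no number reported), so no single number stands for it and it can be placed only below the measured members of the series. Its two measured relatives keep the same peptide core but carry a different group on the aromatic carbon: compound 2 `CCCC[C@H](NC(=O)[C@H](CCCCN)NC(=O)[C@H](CCCNC(=N)N)NC(=O)c1ccc(/C=C2\SC(=O)N(CCCC)C2=O)cc1)C(N)=O` gives 1.18 10^-6 cm/s in this assay, and compound 3 `CCCC[C@H](NC(=O)[C@H](CCCCN)NC(=O)[C@H](CCCNC(=N)N)NC(=O)c1ccc(/C=C2\SC(=S)N(CCCC)C2=O)cc1)C(N)=O` gives 1.61 10^-6 cm/s. Going by the values given here, the only measured step, a 1.4-fold higher number from compound 2 to compound 3 (0.13 log units; within the scatter), concerns that ring exchange and not the change that leads to compound 4 `CCCC[C@H](NC(=O)[C@H](CCCCN)NC(=O)[C@H](CCCNC(=N)N)NC(=O)c1cccs1)C(N)=O`, which is thiophen-2-yl in place of 4-(2-carbamoylethenyl)phenyl on a carbonyl carbon. Among the compounds with values here, no measured pair bears directly on this replacement; the data show only that compound 1 sat without a number in this assay while compounds 2 and 3 gave low single numbers. Compound 4 keeps the charged arginine and lysine side chains of the shared core, so a low reading is expected, near the values of compounds 2 and 3 or under them. The estimate for compound 4 in this assay is 0.6 10^-6 cm/s, expected within 0.1 10^-6 cm/s to 2 10^-6 cm/s.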

Compound 4, apparent permeability: "impermeable" (no number reported)
Compound 4 has no reported number here, so the estimate cannot be set against anything.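

In this assay, going by these compounds alone, compound 1 and compound 4 both stand without a number, so no step between them can be read. Nothing shown offers an explanation for this result. Left open is how far thiophen-2-yl in place of 4-(2-carbamoylethenyl)phenyl shifts permeability on the shared core.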